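The source may report more compounds than this note shows. Statements on the series, on what has been measured and on what is new or still open speak of the compounds shown alone.

Working notes on the series. In a functional assay on U-251 cells (Homo sapiens) for antiproliferative activity, read by MTT assay, with a stated time of 48 h (a lower number here means a stronger inhibitor, a higher number a weaker inhibitor), compound 1 (`COc1ccc(-c2nc3cccc(-c4cc(OC)c(OC)c(OC)c4)c3o2)cc1F`) gives 1700 nM and compound 2 (`COc1cc(-c2cccc3nc(-c4ccc(Cl)cc4)oc23)cc(OC)c1OC`) gives 1600 nM while compound 3 (`COc1cc(-c2cccc3nc(-c4ccc(C)cc4)oc23)cc(OC)c1OC`) gives 3200 nM as its value. Compound 3 therefore lies within the scatter of both others, and no order among the three can be read.

The next compound is compound 4 (`COc1cc(-c2cccc3nc(-c4ccc(N)cc4)oc23)cc(OC)c1OC`), which carries amino in place of methyl on an aromatic carbon, para to a large group (amino in place of methyl on an aromatic carbon). The closest measured change at that place is a 2.0-fold higher number from compound 2 to compound 3 (0.30 log units; within the scatter) with methyl in place of chloro. The steps of a 1.1-fold lower number from compound 1 to compound 2 (0.03 log units; within the scatter) and a 1.9-fold higher number from compound 1 to compound 3 (0.27 log units; within the scatter) replace the whole substituted phenyl group and also remain within the scatter. Within the data shown here, no amino compound has been measured, so the direction stays open, and no step beyond the scatter is expected in this assay on this evidence. The estimated change is a 1.6-fold lower number from compound 3 to compound 4 (0.20 log units; within the scatter) and no more. Compound 4 is expected at 2000 nM with an estimated range of 700 nM to 5500 nM for now.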

Compound 4, half-maximal inhibitory concentration: 1040 nM
Beside the measured number, compound 4's estimate is 1.9-fold (0.28 log units) above it; the range from low to high includes it.
By their numbers in this assay, from the lowest: compounds 4, 2, 1 and 3 (each within the scatter of the next, the first and the last beyond it).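

In this assay, among these compounds, amino in place of methyl on an aromatic carbon, para to a large group, gives a 3.1-fold lower number from compound 3 to compound 4 (0.49 log units; beyond the scatter), the only step beyond the scatter, so a change at this position can separate two compounds. The other two comparisons give a 1.5-fold lower number from compound 2 to compound 4 (0.19 log units; within the scatter) and a 1.6-fold lower number from compound 1 to compound 4 (0.21 log units; within the scatter), so amino stands apart from methyl only and not from chloro or from the 3-fluoro-4-methoxyphenyl compound. No measurement at hand bears on why amino and methyl differ here.

Going by these compounds, what a hydroxyl, a dimethylamino or an acetamido group would give at this place stays open. Also open, on these data alone, is whether the step from methyl to amino would hold with the rest of the shared core changed.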